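The source may hold more compounds than are shown below. What is called first, only, known or untested is meant among the compounds shown, and "the series" means these compounds.

Working notes on the series, read in a functional assay on HepG2 cells (Homo sapiens) for cytotoxicity, with a stated time of 72 h; on this read-out higher numbers stand for an effect only at larger amounts of compound and lower numbers for an effect already at smaller amounts.

Compound 1 `COc1ccc(/C=C/[C@@](C)(/C=C/c2ccc(O)c(/C=C/C(=O)OCc3ccccc3)c2)CCC=C(C)C)cc1` is the odd member, with a different shared core. In this assay compound 1 gives > 26000 nM, which is a limit of the assay and not a number. Compound 2 `C=C[C@@](C)(/C=C/c1ccc(Nc2ccc(OC)c(OC)c2)cc1)CCC=C(C)C` opens the second core. In this assay compound 2 gives > 52000 nM, again a limit. Compound 3 `C=C[C@@](C)(/C=C/c1ccc(Nc2ccc(OC)c(F)c2)cc1)CCC=C(C)C` differs from compound 2 only by fluoro in place of methoxy on an aromatic carbon. In this assay compound 3 gives > 52000 nM, once more a limit. The step that the two limits leave unreadable from compound 2 to compound 3 is therefore unreadable. Where compound 3 stands: every value shown is a limit, two at the limit of > 52000 nM in this assay, at which 2 of the 3 values shown sit, and one at the limit of > 26000 nM in this assay, at which 1 of the 3 values shown sits, so no member of the set has yet shown an effect within the tested range.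

Compound 4 `C=C[C@@](C)(/C=C/c1ccc(Nc2ccc(Cl)c(Cl)c2)cc1)CCC=C(C)C` is the next member. Difference from compound 3: 3,4-dichlorophenyl in place of 3-fluoro-4-methoxyphenyl on a nitrogen on an aromatic ring. Going by the values given here, no measured step bears on this change, and the single step in the set is unreadable, so there is no basis for expecting a departure from the pattern of limits. The expected step is a number no higher from compound 3 to compound 4 (the limit leaves the size open), a guess rather than a reading. For compound 4 the estimate is 52000 nM, within 15000 nM to 150000 nM, most likely reported again as a limit.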

Compound 4, half-maximal effective concentration: > 52000 nM
Compound 4 ended at the assay's limit; the forecaster's own chance of this, stated with the estimate: 70%; the middle value sits exactly at the limit.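

In this assay compound 3 gives > 52000 nM, a limit of the assay and not a number. Compound 4 gives > 52000 nM, also a limit, so no step can be read between these two compounds. The compounds shown leave open whether any member of the series has an effect within the tested range.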